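The source may report more compounds than this note shows. Statements on the series, on what has been measured and on what is new or still open speak of the compounds shown alone.

In an ADME assay on MT4 cells (Homo sapiens) for cytotoxicity, read by MTT assay, with a stated time of 96 h (a higher number here means that more compound is tolerated, a lower number that less compound is tolerated), compound 1 (`Cc1ccc(/N=N/N(C)c2ccccc2)cc1`) gives 45000 nM. Compound 2 (`Clc1cccc(/N=N/N2CCCCC2)c1`) gives > 100000 nM, which is a limit of the assay and not a number. Within the data shown here, these two compounds differ in more than one place, so no measured step is available to size a single change. Compound 3 (`Brc1cccc(/N=N/N2CCCCC2)c1`) differs from compound 2 by one swap, bromo in place of chloro on an aromatic carbon. Among the measured compounds shown here, with no measured step to draw on, the expectation in this assay is for no shift beyond the usual scatter, in either direction. The expected change an at least 1.1-fold lower number from compound 2 to compound 3 (0.07 log units; that floor lies within the scatter) is therefore small. A report of compound 3 as a limit again would fit this expectation. For compound 3 the estimated value is 85000 nM, with an expected range of 35000 nM to 100000 nM.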

Compound 3, half-maximal cytotoxic concentration: > 100000 nM
Compound 3 gave a limit, no number (the forecaster's own chance of this, stated with the estimate: 60%); middle value at least 1.1-fold (0.07 log units) from the limit.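

In this assay, compound 2 and compound 3 are both reported as limits and not numbers, so no step can be read between them: the limit of > 100000 nM in this assay, at which 2 of the 3 values shown sit.

The compounds shown leave open whether bromo in place of chloro on an aromatic carbon shifts the tolerated concentration at all.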